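Adding carbons to the side chain of compound 3

A few compounds are considered here, and "the series" means these few. Any claim that something is new, unique, unknown or untested is made for them only; others in the source may bear on it.

In a physicochemical assay for solubility, at pH 7.4 (on this read-out lower numbers stand for lower solubility and higher numbers for higher solubility), compound 1 `CC(=O)N1CCc2c(C)c3c(n2-c2ccc(C(N)=O)c(c2)N[C@@H](C)[C@H](C)C1)CC(C)(C)CC3=O` gives 38 ug/mL, compound 2 `Cc1c2c(n3c1CCN(C(=O)C1(N)CC1)C[C@@H](C)[C@H](C)Nc1cc-3ccc1C(N)=O)CC(C)(C)CC2=O` gives 7 ug/mL and compound 3 `Cc1c2c(n3c1CCN(C(=O)[C@H](C)O)C[C@@H](C)[C@H](C)Nc1cc-3ccc1C(N)=O)CC(C)(C)CC2=O` gives 60 ug/mL. Compound 3 and compound 1 lie within the scatter of each other, and both stand clear of compound 2.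

Compound 4 `Cc1c2c(n3c1CCN(C(=O)[C@@H](O)C(C)C)C[C@@H](C)[C@H](C)Nc1cc-3ccc1C(N)=O)CC(C)(C)CC2=O` keeps the shared core of compound 3 and alters one group: isopropyl in place of methyl on a saturated chain carbon bound to a carbonyl carbon and an oxygen on a saturated carbon. This places isopropyl where methyl stood, on a saturated chain carbon bound to a carbonyl carbon and an oxygen on a saturated carbon.

Among the measured compounds shown here, no measured step tests this exact change, but all three altered the group on a carbonyl carbon and so set the scale. The smallest, a 1.6-fold higher number from compound 1 to compound 3 (0.20 log units; within the scatter), stayed within the scatter. The other two were larger: a 5.4-fold lower number from compound 1 to compound 2 (0.73 log units; beyond the scatter) and an 8.6-fold higher number from compound 2 to compound 3 (0.93 log units; beyond the scatter). Here only carbon enters, with no hydrogen-bond donors or acceptors, so a modest fall in this assay is expected rather than a large one.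

The expected change is a 2.4-fold lower number from compound 3 to compound 4 (0.38 log units; beyond the scatter).

For compound 4 the estimated value is 25 ug/mL, with an expected range of 8 ug/mL to 70 ug/mL.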

Compound 4, solubility: 30 ug/mL
The estimate for compound 4 lay 1.2-fold (0.08 log units) below the measured number; the measured number falls inside the stated range.
By their numbers in this assay, from the lowest: compound 2; then compounds 4, 1 and 3 (each within the scatter of the next).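

In this assay, this is the first change shown at this saturated chain carbon, and the step, a 2.0-fold lower number from compound 3 to compound 4 (0.30 log units; within the scatter), shows that swapping methyl for isopropyl, which adds carbon but no hydrogen-bond donors or acceptors, gives no readable difference. The wider comparison holds as well: a 1.3-fold lower number from compound 1 to compound 4 (0.10 log units; within the scatter), whereas a 4.3-fold higher number from compound 2 to compound 4 (0.63 log units; beyond the scatter), so the 1-hydroxy-2-methylpropyl group stays level with methyl on the carbonyl carbon and remains clear of 1-aminocyclopropyl. No evidence is available to explain these numbers.

This single step cannot show how much carbon this position tolerates, so a tert-butyl group or a longer chain might still give a step beyond the scatter. From the compounds shown here alone, how an amine or a carboxylic acid in place of methyl at this carbon would read also remains open.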